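This account rests on a few compounds, and the source may have more. Where it says the series, first, only, none or still open, it means among the compounds named here.

Three compounds of this series have numbers in a functional assay on JAR cells (Homo sapiens) for inhibition, read by MTT assay, with a stated time of 72 h, tested at 10 uM; a higher number here means more inhibition at the concentration tested (going by the name of the read-out), a lower number less inhibition. Compound 1 `CCOC(=O)C1=C(Nc2ccccc2)S/C(=C\c2cccc(C(=O)O)c2)C1=O` gives 50.6%, compound 2 `CCOC(=O)C1=C(Nc2ccccc2)S/C(=C\c2cc(OC)c(O)c(OC)c2)C1=O` gives 57.5%, and compound 3 `CCOC(=O)C1=C(Nc2ccccc2Br)S/C(=C\c2ccc[nH]2)C1=O` gives 62.7%. Compound 3 has the highest number of the three; its gap to compound 2 lies within the scatter, while its gap to compound 1 lies beyond it. Compound 4 `CCOC(=O)C1=C(Nc2cccc([N+](=O)[O-])c2)S/C(=C\c2ccc[nH]2)C1=O` is not yet measured. It differs from compound 3 in one place (3-nitrophenyl in place of 2-bromophenyl on an amine nitrogen). Among the measured compounds shown here, no measured pair shows such a change on the amine nitrogen, so nothing in the numbers points to a large effect. The step from compound 3 to compound 4 is expected to be small and downward, a number 7.7 percentage points lower from compound 3 to compound 4 (within the scatter), within the scatter. Compound 4 is therefore estimated at 55%, in the range 35% to 75%.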

Compound 4, a percentage reported as inhibition, at one concentration (the size of the read-out at that concentration, not a potency): 57.4%
For compound 4 the middle estimate is 2.4 percentage points below the measured one, and the stated range covers the measured number.
By their numbers in this assay, from the lowest: compounds 1, 4, 2 and 3 (each within the scatter of the next, the first and the last beyond it).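

Among the compounds shown here, this pair gives the first one-place change on the amine nitrogen in this assay: 3-nitrophenyl in place of 2-bromophenyl gives a number 5.3 percentage points lower from compound 3 to compound 4 (within the scatter). This position therefore accepts the exchange of these two substituted phenyl groups without a step beyond the scatter. Nothing available bears on the reason for this step.

Still open, as far as these compounds go, is how this position responds to a carboxylic acid or a dimethylamino group on the phenyl ring. Also open, from the compounds shown here alone, is the effect of a plain ethyl chain in place of that ring.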